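This account rests on a few compounds, and the source may have more. Where it says the series, first, only, none or still open, it means among the compounds named here.

Compound 3 `O=C(Nc1ccc(Sc2nc3ccccc3s2)c(Cl)c1)c1ccccc1` shares its core with compound 1 `O=C(Nc1ccc(Sc2nc3ccccc3s2)c(Cl)c1)c1ccccc1O` and compound 2 `O=C(Nc1ccc(Sc2nc3ccccc3s2)c(Cl)c1)c1cccc(Br)c1`. In an assay on isolated protein for inhibition of thiosulfate sulfurtransferase (Homo sapiens), with a stated time of 60 min, in the absence of a further agent (a higher number here means a weaker inhibitor, a lower number a stronger inhibitor), compound 3 gives only a limit, > 100000 nM. Compound 1 likewise gives only a limit in this assay, > 100000 nM. Compound 2 also gives only a limit in this assay, > 100000 nM. The three steps a step that the two limits leave unreadable from compound 1 to compound 2, a step that the two limits leave unreadable from compound 1 to compound 3 and a step that the two limits leave unreadable from compound 2 to compound 3 are therefore unreadable, since every value sits at the limit of > 100000 nM in this assay, at which 3 of the 3 values shown sit. Compound 4 `O=C(Nc1ccc(Sc2nc3ccccc3s2)c(Cl)c1)c1cc(Br)ccc1O` differs from compound 3 by 5-bromo-2-hydroxyphenyl in place of phenyl on a carbonyl carbon, joining the groups carried separately by compound 1 and compound 2. No measured step reads, so no direction can be drawn from the shown numbers. Compound 4 is expected to remain at the limit, estimated at 150000 nM, between 30000 nM and 1000000 nM. The step that the limit leaves unreadable from compound 3 to compound 4 is thus expected to be within the scatter.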

Compound 4, half-maximal inhibitory concentration: > 100000 nM
Compound 4: a limit, no number (the forecaster's own chance of this, stated with the estimate: 85%); the middle value is on the limit's open side.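

The steps from compound 1, compound 2 and compound 3 to compound 4 cannot be read, as all four compounds give only a limit: the limit of > 100000 nM in this assay, at which 4 of the 4 values shown sit.

The compounds shown leave open whether any change on the shared core yields a measurable value in this assay.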